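Urea in place of amide on a pyrazole series

The source may hold more compounds than are shown below. What is called first, only, known or untested is meant among the compounds shown, and "the series" means these compounds.

Three compounds share a core carrying a pyridine, a substituted phenyl and a phenyl bearing a carbonyl-linked group. Compound 1 `O=C(Nc1cccc(-n2cc(-c3ccncc3)c(-c3ccc(Cl)c(O)c3)n2)c1)Nc1cccc(C(F)(F)F)c1` carries a urea and a hydroxyl on the chlorophenyl. In a functional assay on ACHN cells (Homo sapiens) for inhibition, read by sulforhodamine B assay, with a stated time of 48 h (a higher number here means a weaker inhibitor of growth, a lower number a stronger inhibitor of growth), compound 1 reaches only a limit, > 32500 nM. Compound 2 `COc1cc(-c2nn(-c3cccc(NC(=O)Nc4cc(C(F)(F)F)cc(C(F)(F)F)c4)c3)cc2-c2ccncc2)ccc1Cl` carries a urea and a methoxy group, and in this assay compound 2 gives 5720 nM. Compound 3 `COc1cc(-c2nn(-c3cccc(NC(=O)c4cccc(C(F)(F)F)c4)c3)cc2-c2ccncc2)ccc1Cl` carries a simple amide instead of a urea, and in this assay compound 3 stands at a limit, > 50000 nM; this is the limit described by the limit of > 50000 nM in this assay, at which 1 of the 3 values shown sits, while compound 1 sits at the limit described by the limit of > 32500 nM in this assay, at which 1 of the 3 values shown sits. Compound 4 `COc1cc(-c2nn(-c3cccc(NC(=O)Nc4ccc(Cl)c(Cl)c4)c3)cc2-c2ccncc2)ccc1Cl` has not yet been measured. It differs from compound 3 by (3,4-dichlorophenyl)amino in place of 3-(trifluoromethyl)phenyl on a carbonyl carbon, which restores a urea as in compound 2. Because compound 2 gives 5720 nM, the step is expected to go toward stronger growth inhibition, with an at least 6.2-fold lower number from compound 3 to compound 4 (0.79 log units; beyond the scatter) expected. Compound 4 is estimated at 8000 nM, within a range of 2000 nM to 40000 nM.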

Compound 4, concentration for total growth inhibition: > 50000 nM
Compound 4 ended at the assay's limit (the forecaster's own chance of this, stated with the estimate: 25%); at least 6.2-fold (0.79 log units) between middle value and limit.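

In this assay, among these compounds, compound 3 and compound 4 each end at a limit, not at a number, and no step between them can be read. The compounds shown leave open how strongly either one inhibits growth, and whether the urea of compound 4 differs from the amide of compound 3 at all.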